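Methyl ester of a pentaene oxo acid, estimated

A few compounds are considered here, and "the series" means these few. Any claim that something is new, unique, unknown or untested is made for them only; others in the source may bear on it.

In a functional assay on cells for agonist activity at Oxoeicosanoid receptor 1 (Homo sapiens), read by beta-arrestin recruitment (a higher number here means that more compound is needed for the effect, a lower number that less compound is needed), compound 1, `CC/C=C\C/C=C\C/C=C\C/C=C\C=C\C(=O)CCCC(=O)OC`, gives 2080 nM. Compound 2, `CC/C=C\C/C=C\C/C=C\C/C=C\C/C=C\C=C\C(=O)CCC(=O)O`, reaches only the limit of this assay, > 100000 nM, so no number is known for it; this is the limit named in the limit of > 100000 nM in this assay, at which 1 of the 2 values shown sits. Compound 3, `CC/C=C\C/C=C\C/C=C\C/C=C\C/C=C\C=C\C(=O)CCC(=O)OC`, differs from compound 2 by methyl in place of hydrogen on an oxygen next to a carbonyl group. Since compound 2 gives only a limit, the step from compound 2 to compound 3 cannot be sized from the numbers, yet the ester compound 1 is active in this assay. Compound 3 is therefore expected to fall at about 3000 nM, between 800 nM and 20000 nM, a step of an at least 33-fold lower number from compound 2 to compound 3 (1.52 log units; beyond the scatter) toward lower concentration.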

Compound 3, half-maximal effective concentration: > 100000 nM
Compound 3: no number, only a limit; the forecaster's own chance of this, stated with the estimate: 20%; middle value at least 33-fold (1.52 log units) away from the limit.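

Compound 2 and compound 3 both give only limits in this assay, so no step between them can be read: the limit of > 100000 nM in this assay, at which 2 of the 3 values shown sit.

Going by these compounds, whether methyl in place of hydrogen on an oxygen next to a carbonyl group changes the response in this assay at all stays open.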